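Thiosemicarbazone series: moving the chloro group around the phenyl

A few compounds are considered here, and "the series" means these few. Any claim that something is new, unique, unknown or untested is made for them only; others in the source may bear on it.

For the measured compounds named here, compound 2 `CC1=CC[C@@H]([C@@](C)(O)CCCC(C)(C)NC(=S)N/N=C\c2ccccc2Cl)CC1` gives 18800 nM in a functional assay on PCO3 cells (Homo sapiens) for cytotoxicity, read by sulforhodamine B assay (on this read-out higher numbers stand for weaker inhibition of growth and lower numbers for stronger inhibition of growth), the higher of the two numbers measured so far; compound 1 `CC1=CC[C@@H]([C@@](C)(O)CCCC(C)(C)NC(=S)N/N=C\c2ccccc2)CC1` gives 8470 nM in this assay. Going by the values given here, the single measured step is a 2.2-fold higher number from compound 1 to compound 2 (0.35 log units; beyond the scatter). Compound 3 `CC1=CC[C@@H]([C@@](C)(O)CCCC(C)(C)NC(=S)N/N=C\c2ccc(Cl)cc2)CC1` differs from compound 2 by 4-chlorophenyl in place of 2-chlorophenyl on a carbon with a double bond to nitrogen. Among the compounds with values here, no measured step relocates a chloro group on the phenyl ring, so the step from compound 1 to compound 2 bears only loosely on this change. The expected step is therefore none beyond the scatter, a 1.2-fold lower number from compound 2 to compound 3 (0.07 log units; within the scatter). Compound 3 is expected to give 16000 nM in this assay, within a range from 6000 nM to 45000 nM.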

Compound 3, concentration for 50% growth inhibition: 7580 nM
Beside the measured number, compound 3's estimate is 2.1-fold (0.32 log units) above it; measured number inside the range.
By their numbers in this assay, from the lowest: compounds 3 and 1 (each within the scatter of the next); then compound 2.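

In this assay the place of the chloro group on the phenyl ring counts: a 2.5-fold lower number from compound 2 to compound 3 (0.39 log units; beyond the scatter) is a step beyond the scatter, with the same atoms joined differently. With 4-chlorophenyl, a 1.1-fold lower number from compound 1 to compound 3 (0.05 log units; within the scatter) stays within the scatter, so the rise seen with 2-chlorophenyl, a 2.2-fold higher number from compound 1 to compound 2 (0.35 log units; beyond the scatter), does not carry over to 4-chlorophenyl. Nothing at hand explains the difference between the two placements. Open, on these data alone, is whether this dependence on place is particular to chloro or also holds for other groups on the phenyl ring, such as methoxy or an amine.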